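The source may hold more compounds than are shown below. What is called first, only, known or untested is meant among the compounds shown, and "the series" means these compounds.

Among the compounds with values here, in a functional assay on HeLa cells (Homo sapiens) for cytotoxicity, read by neutral red uptake, with a stated time of 3 days (on this read-out lower numbers stand for stronger inhibition and higher numbers for weaker inhibition), compound 3 `COc1c(F)c(N)c2c(=O)cc(-c3ccc(N)c(F)c3)oc2c1F` gives 34000 nM, and it is the only compound in this set for which a number, rather than a limit, is reported. Compound 1 `CCc1c(F)c(N)c2c(=O)cc(-c3ccc(N)c(F)c3)oc2c1F` gives > 100000 nM in this assay, which is a limit of the assay. Compound 2 `C[S+]([O-])c1c(F)c(N)c2c(=O)cc(-c3ccc(N)c(F)c3)oc2c1F` likewise gives > 100000 nM, again a limit of the assay. The step that the two limits leave unreadable from compound 1 to compound 2 is therefore not readable. The two steps that reach compound 3 are an at least 2.9-fold lower number from compound 1 to compound 3 (0.46 log units; beyond the scatter) and an at least 2.9-fold lower number from compound 2 to compound 3 (0.46 log units; beyond the scatter), both at the same aromatic carbon of the shared core, so the methoxy group is the one substituent at that position that brings the read-out inside the measured range.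

Compound 4 `Nc1ccc(-c2cc(=O)c3c(N)c(F)c(Cl)c(F)c3o2)cc1F` differs from compound 3 by chloro in place of methoxy on an aromatic carbon. Since the two measured steps to compound 3 both run from a limit to a number, a chloro group at this position is expected to give a step of a 2.4-fold higher number from compound 3 to compound 4 (0.37 log units; beyond the scatter) back toward weaker inhibition. Compound 4 is therefore estimated at 80000 nM, with a range from 20000 nM to 300000 nM, and a real chance that only a limit is reported.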

Compound 4, half-maximal inhibitory concentration: > 100000 nM
Compound 4 gave a limit, no number; the forecaster's own chance of this, stated with the estimate: 50%; middle value at least 1.2-fold (0.09 log units) from the limit.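

In this assay, chloro now joins ethyl and the sulfur-bearing group of compound 2 as a group that leaves the read-out at a limit, so methoxy stands apart from three different groups at this aromatic carbon rather than two. The change from methoxy to chloro gives an at least 2.9-fold higher number from compound 3 to compound 4 (0.46 log units; beyond the scatter), which shows that a group of a single heavy atom does not bring the read-out inside the measured range here either. The steps among compound 1, compound 2 and compound 4 cannot be read, since all three sit at one limit of the assay: the limit of > 100000 nM in this assay, at which 3 of the 4 values shown sit.

Going by these compounds, how far these three compounds lie from one another past that limit stays open. On these data alone, it also stays open whether ethoxy, a hydroxyl or an amine at this carbon would give a number, since the only one so far belongs to compound 3 at 34000 nM.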